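The source may report more compounds than this note shows. Statements on the series, on what has been measured and on what is new or still open speak of the compounds shown alone.

In an ADME assay (liver) for metabolic stability, with Liver microsome (Rattus norvegicus) as the target, using microsomes and NADPH, with a stated time of 30 min, tested at 1 uM (a lower number here means slower removal, a higher number faster removal of the compound), compound 1 (`CCn1cc(-c2cc(C(O)(C(F)(F)F)C(F)(F)F)cnc2N2CCN(S(=O)(=O)c3ccc(N)nc3)CC2)cn1`) gives 194 mL.min-1.g-1 and compound 2 (`CC(C)n1cc(-c2cc(C(O)(C(F)(F)F)C(F)(F)F)cnc2N2CCN(S(=O)(=O)c3ccc(N)nc3)CC2)cn1`) gives 198 mL.min-1.g-1 on the same core, while compound 3 (`COc1ccc(-c2cc(C(O)(C(F)(F)F)C(F)(F)F)cnc2N2CCN(S(=O)(=O)c3ccc(N)nc3)CC2)cn1`) gives 265 mL.min-1.g-1 on that core too. Compound 3 therefore stands level with the other two, within the scatter of both. Compound 4 (`Nc1ccc(S(=O)(=O)N2CCN(c3ncc(C(O)(C(F)(F)F)C(F)(F)F)cc3-c3cccc4[nH]ncc34)CC2)cn1`) keeps the shared core and carries 1H-indazol-4-yl in place of 6-methoxypyridin-3-yl on an aromatic carbon. Two measured steps exchange the group at this same carbon (a 1.4-fold higher number from compound 1 to compound 3 (0.14 log units; within the scatter) and a 1.3-fold higher number from compound 2 to compound 3 (0.13 log units; within the scatter)) and both stay within the scatter. The third step (a 1.0-fold higher number from compound 1 to compound 2 (0.01 log units; within the scatter)) only turns the ethyl chain on the pyrazole into isopropyl, and it also stays within the scatter. Among the measured compounds shown here, no measured compound carries an indazolyl group, so the data hold no direct precedent for this exchange. On the evidence of those two steps, and starting from compound 3 with its 265 mL.min-1.g-1 as the reference, no step beyond the scatter is expected in this assay here. The estimated step (a 1.3-fold lower number from compound 3 to compound 4 (0.12 log units; within the scatter)) is accordingly a small one. The estimate for compound 4 is 200 mL.min-1.g-1 within a range from 100 mL.min-1.g-1 to 380 mL.min-1.g-1 in this clearance read-out.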

Compound 4, intrinsic clearance in microsomes: 93 mL.min-1.g-1
Compound 4: middle estimate off by 2.2-fold (0.33 log units), on the high side, and the stated range ends above it.
By their numbers in this assay, from the lowest: compound 4; then compounds 1, 2 and 3 (each within the scatter of the next).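

In this assay, the aromatic carbon ortho to a large group turns out to be a place where an exchange can move the number beyond the scatter, which none of the earlier exchanges among the 1-ethyl-1H-pyrazol-4-yl, 1-isopropyl-1H-pyrazol-4-yl and 6-methoxypyridin-3-yl groups did. The shift to slower removal appears against all three of these groups, as (a 2.8-fold lower number from compound 3 to compound 4 (0.45 log units; beyond the scatter)), (a 2.1-fold lower number from compound 2 to compound 4 (0.33 log units; beyond the scatter)) and (a 2.1-fold lower number from compound 1 to compound 4 (0.32 log units; beyond the scatter)), so it does not depend on which of them is taken as the reference. Nothing available here accounts for this shift.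

The entering 1H-indazol-4-yl differs from 6-methoxypyridin-3-yl at once in its ring count, its 1 hydrogen-bond donor and its loss of the methoxy oxygen, and the compounds shown cannot tell these features apart. On these data alone, a 1-methyl-1H-indazol-4-yl group or a 1H-indol-4-yl group at the same carbon would bear on that question, and whether the lower number goes with the indazole hydrogen on nitrogen or with the two-ring group as a whole remains open.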